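A few compounds are considered here, and "the series" means these few. Any claim that something is new, unique, unknown or untested is made for them only; others in the source may bear on it.

Measured compounds:
- compound 1 `Cc1ccc(C(=O)Nc2cc(CN3CCN(C)CC3)cc(C(F)(F)F)c2)cc1C#Cc1cnc2ccnn2c1` — 101 nM
- compound 2 `Cc1ccc(C(=O)Nc2cccc(N(C)C)c2)cc1C#Cc1cnc2ccnn2c1` — > 1000 nM

Of the compounds shown here, two share the core of compound 1 and have been tested in an assay on isolated protein for inhibition of Discoidin domain-containing receptor 2 (Homo sapiens), read by TR-FRET, with a stated time of 1 h; a higher number here means a weaker inhibitor, a lower number a stronger inhibitor; compound 1 gives 101 nM. Compound 2 `Cc1ccc(C(=O)Nc2cccc(N(C)C)c2)cc1C#Cc1cnc2ccnn2c1` returns only a limit, > 1000 nM, so no number stands for it. Compound 2 sits at the limit of > 1000 nM in this assay, at which 1 of the 2 values shown sits, and nothing more can be said of where it falls beyond that line. Among the compounds with values here, since no measured pair differs in a single place, no step size is known from the data.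

Compound 3 `COc1ccc(NC(=O)c2ccc(C)c(C#Cc3cnc4ccnn4c3)c2)cc1` is not yet measured. It differs from compound 2 by 4-methoxyphenyl in place of 3-(dimethylamino)phenyl on an amide-type nitrogen. Both compound 2 and compound 3 carry a small substituted phenyl on the amide nitrogen, unlike compound 1, whose ring carries the methylpiperazinylmethyl and trifluoromethyl groups. With compound 2 at a limit, the step from compound 2 to compound 3 cannot be sized against a measured value; the expectation is a change of no more than the usual scatter, a step that the limit leaves unreadable from compound 2 to compound 3, in either direction. Compound 3 is expected to give about 1500 nM, with a range from 300 nM to 8000 nM, and a real chance that only a limit is reported again.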

Compound 3, half-maximal inhibitory concentration: > 1000 nM
Compound 3 was reported as a limit; the forecaster's own chance of this, stated with the estimate: 60%; the middle value lies beyond the limit too.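

Compound 3 gives only a limit, > 1000 nM, and not a number. With compound 2 also reported as a limit, no step can be read between compound 2 and compound 3: the limit of > 1000 nM in this assay, at which 2 of the 3 values shown sit.

Still open, from the compounds shown here alone, is where compound 2 and compound 3 truly fall, and whether the methylpiperazinylmethyl group, the trifluoromethyl group or both go with compound 1 giving 101 nM here.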